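Series notes: trifluoromethyl in place of chloro

The source may report more compounds than this note shows. Statements on the series, on what has been measured and on what is new or still open speak of the compounds shown alone.

Compound 1 `Cc1cc(-c2sc(Cc3cccc(F)c3)nc2C)ccc1C(N)=O` gives 75% in a functional assay on cells for agonist activity at G-protein coupled receptor 52 (Homo sapiens), read by AlphaScreen and cAMP accumulation, with a stated time of 30 min; a lower number here means a smaller maximal response, a higher number a larger maximal response. Compound 2 `Cc1cc(-c2sc(Cc3cc(F)cc(Cl)c3)nc2C)ccc1C(N)=O` gives 88% in this assay; chloro in place of hydrogen on an aromatic carbon gave a number 13 percentage points higher from compound 1 to compound 2 (beyond the scatter). Among the measured compounds shown here, compound 2 thus stands highest of the two numbers so far, with compound 1 nearest and lower by that step. Compound 3 `Cc1cc(-c2sc(Cc3cc(F)cc(C(F)(F)F)c3)nc2C)ccc1C(N)=O` is not yet measured. From compound 2 to compound 3 the difference is trifluoromethyl in place of chloro on an aromatic carbon. For the measured compounds named here, no measured step exchanges chloro for trifluoromethyl; the single step so far concerns the arrival of chloro on that ring, not its replacement, and so bears only loosely on the question. Both exchanged groups sit on the same aromatic carbon, so little movement beyond the scatter is foreseen. The expected step is therefore no change at the digits printed from compound 2 to compound 3 (within the scatter), within the scatter. The estimate for compound 3 in this assay is 88%, ranging from 74% to 100%.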

Compound 3, largest response reached (Emax), in percent of the reference or control that the assay uses: 93%
The estimate for compound 3 lay 5 percentage points below the measured number; the measured number falls inside the stated range.
By their numbers in this assay, from the lowest: compound 1; then compounds 2 and 3 (each within the scatter of the next).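

Among the compounds shown here, at this aromatic carbon, meta to a fluoro group, trifluoromethyl in place of chloro gave a number 5 percentage points higher from compound 2 to compound 3 (within the scatter) in this assay, so the position accepts the group of 4 heavy atoms in place of the single chlorine with no change beyond the scatter. Trifluoromethyl in place of hydrogen gave a number 18 percentage points higher from compound 1 to compound 3 (beyond the scatter), so the higher maximal response over compound 1 is no longer tied to chloro alone and holds for both compound 2 and compound 3. Nothing available on these compounds accounts for this result.

On these data alone, what a methoxy group, a nitrile or an amine on the same carbon would give remains open. As far as these compounds go, with only the largest response to go on, the potency of compound 2 and compound 3 also remains open.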